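Cytotoxicity notes on three measured compounds and one pending

The compounds below may be only part of what the source reports. "The series", "measured", "known", "first", "only" and "open" are said of these compounds alone.

compound 1 `CN1CCN(CCNCc2cn(-c3ccc(F)cc3F)nc2C2CCCCC2)CC1` — > 20000 nM
compound 2 `Cc1ccccc1-c1nn(-c2ccc(F)cc2F)cc1CNCCN1CCCCC1` — > 20000 nM
compound 3 `Cc1ccccc1-c1nn(-c2ccc(OC(F)(F)F)cc2)cc1CNCCN1CCN(C)CC1` — 17000 nM

In an ADME assay on Huh-7 cells (Homo sapiens) for cytotoxicity (a higher number here means that more compound is tolerated, a lower number that less compound is tolerated), compound 1 gives > 20000 nM, which is a limit of the assay and not a number. Compound 2 likewise gives > 20000 nM, again a limit rather than a number. Within the data shown here, compound 3 gives 17000 nM, the only actual number in the set. The other two values are limits of the assay, so compound 3 cannot be ranked against compound 1 or compound 2 in this assay.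

Compound 4 `Cc1ccccc1-c1nn(-c2ccc(F)cc2F)cc1CNCCN1CCN(C)CC1` is still to be measured in this assay. Against compound 3 it differs by 2,4-difluorophenyl in place of 4-(trifluoromethoxy)phenyl on an aromatic nitrogen. Among the measured compounds shown here, no step between measured compounds is available to gauge this change directly. What the remaining values show is that compound 1 and compound 2, which carry the same 2,4-difluorophenyl group as compound 4, both sit at the limit, and the limit of > 20000 nM in this assay, at which 2 of the 3 values shown sit, is the main pointer for where the series tends to fall.

The step from compound 3 to compound 4 is expected to be small, a 1.3-fold higher number from compound 3 to compound 4 (0.11 log units; within the scatter), if anything toward more compound tolerated and likely not beyond the scatter. Compound 4 is estimated at 22000 nM, within a range of 12000 nM to 40000 nM, with a fair chance that only the limit is reported.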

Compound 4, half-maximal cytotoxic concentration: > 20000 nM
Compound 4 ended at the assay's limit; the forecaster's own chance of this, stated with the estimate: 60%; the middle value lies beyond the limit too.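

Among these compounds, at the aromatic nitrogen, the first reading for 2,4-difluorophenyl in place of 4-(trifluoromethoxy)phenyl in this assay is an at least 1.1-fold higher number from compound 3 to compound 4 (0.07 log units; that floor lies within the scatter), so this change gives no sign of less compound being tolerated. From the compounds shown here alone, compound 4 gives > 20000 nM, which is a limit of the assay and not a number, so the true size of this step stays unknown. The steps to compound 4 from compound 1 and from compound 2 cannot be read, and the overall picture for the series remains: the limit of > 20000 nM in this assay, at which 3 of the 4 values shown sit.

Going by these compounds, with only compound 3 giving an actual number in this assay, it remains open whether any group on this aromatic nitrogen shifts tolerance by more than the scatter, or whether 4-(trifluoromethoxy)phenyl would also give a number with piperidin-1-yl in place of 4-methylpiperazin-1-yl. On these data alone, it is also open whether a phenyl ring carrying a carboxylic acid or a primary amine at this nitrogen would bring the value within the readable range of the assay.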